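This account rests on a few compounds, and the source may have more. Where it says the series, first, only, none or still open, it means among the compounds named here.

In a functional assay on U-937 cells (Homo sapiens) for antiproliferative activity, read by MTT assay, with a stated time of 72 h (a lower number here means a stronger inhibitor, a higher number a weaker inhibitor), compound 1 `O=C(CCCCCCc1nc(-c2cccc([N+](=O)[O-])c2)no1)NO` gives 1160 nM as its reading. Among the measured compounds shown here, the only other measured compound, compound 2 `O=C(CCCCCCc1nc(-c2cccnc2)no1)NO`, gives 350 nM in the same test. Compound 1 therefore holds the higher of the two numbers, and the gap between them lies beyond the usual scatter, so it is the weaker inhibitor of the pair.

Compound 3 `Nc1ccccc1NC(=O)CCCCCCc1nc(-c2cccc([N+](=O)[O-])c2)no1` keeps the core of compound 1 and differs in one place, where the change 2-aminophenyl in place of hydroxy on an amide-type nitrogen puts 2-aminophenyl in place of hydroxy on an amide-type nitrogen. Hydroxycarbamoyl thus becomes (2-aminophenyl)carbamoyl. For the measured compounds named here, no measured pair shows this change, so the data offer no direct guide to its size, and any expectation carries wide uncertainty. In this assay a moderate move towards a higher number, beyond the scatter, is expected, which would make compound 3 the weaker inhibitor. The estimated step of a 2.6-fold higher number from compound 1 to compound 3 (0.41 log units; beyond the scatter) is only an expectation until a measurement exists. For compound 3 the estimated value is 3000 nM with an expected range from 800 nM to 12000 nM in this test.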

Compound 3, half-maximal inhibitory concentration: 2150 nM
Compound 3: middle estimate off by 1.4-fold (0.14 log units), on the high side, within the range that was stated.
By their numbers in this assay, from the lowest: compound 2; then compounds 1 and 3 (each within the scatter of the next).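

Among the compounds shown here, compounds 1 and 2 both carry hydroxy on the amide-type nitrogen, so they said nothing about this position; compound 3 is the first to vary it. In this assay, putting 2-aminophenyl in place of hydroxy gives a 1.9-fold higher number from compound 1 to compound 3 (0.27 log units; within the scatter), so this single pair shows no separation between the two groups, even though 1 heavy atom with no ring gives way to 7 heavy atoms with one six-membered aromatic ring of carbon only. Nothing measured here bears on why the exchange leaves the reading within the scatter, so the result stands as an observation without an explanation.

Going by these compounds, because this is one pair on one core in one cell assay, it remains open whether 2-aminophenyl in place of hydroxy would give a similar step on the core of compound 2, which holds the lowest number of the three. Also open, on these data alone, is how a carboxylic acid, a plain primary amide or a 2-hydroxyphenyl group on the same carbonyl would read in this assay, and whether a longer chain would alter the picture.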